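Ester in Place of Thioester on the Carbonyl Carbon

The source may hold more compounds than are shown below. What is called first, only, known or untested is meant among the compounds shown, and "the series" means these compounds.

Compound 1 `CC1=C(C(=O)NC(C)C)C(c2ccsc2)NC(=O)N1`: 1%
Compound 2 `CCN(CC)C(=O)C1=C(C)NC(=O)NC1c1ccsc1`: 35%
Compound 3 `CC1=C(C(=O)SC(C)C)C(c2ccsc2)NC(=O)N1`: 1%

Of the compounds shown here, three sharing one core have been tested in an assay on membranes from HeLa cells for displacement of a labelled ligand from adenosine receptor A3 (Homo sapiens), read by scintillation counting, with a stated time of 180 min, tested at 1 uM; a lower number here means less inhibition, a higher number more inhibition at the concentration tested (going by the name of the read-out). Compound 1 gives 1%, compound 2 gives 35% and compound 3 gives 1%. Compound 3 thus stands level with compound 1, the two together being the lowest of the three numbers; the only large movement among them is a number 34 percentage points lower from compound 2 to compound 3 (beyond the scatter), while no change at the digits printed from compound 1 to compound 3 (within the scatter).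

Compound 4 `CC1=C(C(=O)OCC2CC2)C(c2ccsc2)NC(=O)N1` differs from compound 3 in one place: cyclopropylmethoxy in place of isopropylsulfanyl on a carbonyl carbon. Among the measured compounds shown here, two measured steps touch the same carbonyl carbon. The exchange of isopropylamino for isopropylsulfanyl left the number unchanged, as no change at the digits printed from compound 1 to compound 3 (within the scatter) shows, whereas the exchange of diethylamino for isopropylsulfanyl produced the large fall a number 34 percentage points lower from compound 2 to compound 3 (beyond the scatter). For the measured compounds named here, neither step involves cyclopropylmethoxy, so no measured pair bears directly on the new group. With two of three groups on this carbon giving the same low number, compound 4 is expected to stay near compound 3, with a step of a number 5 percentage points higher from compound 3 to compound 4 (within the scatter) not beyond the scatter. The estimate for compound 4 in this assay is therefore 6%, within a range from 0% to 25%.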

Compound 4, a percentage reported as inhibition, at one concentration (the size of the read-out at that concentration, not a potency): 3%
Compound 4: middle estimate off by 3 percentage points, on the high side, within the range that was stated.
By their numbers in this assay, from the lowest: compounds 1, 3 and 4 (each within the scatter of the next); then compound 2.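

In this assay, a third kind of group on this carbonyl carbon, now linked through oxygen and carrying a three-membered ring, shows a number 2 percentage points higher from compound 3 to compound 4 (within the scatter) and a number 2 percentage points higher from compound 1 to compound 4 (within the scatter), so cyclopropylmethoxy joins isopropylsulfanyl and isopropylamino at the low end of the series. Against this group, diethylamino remains the one exception among the four compounds, with a number 32 percentage points lower from compound 2 to compound 4 (beyond the scatter), so the result widens the contrast from two low compounds to three and leaves compound 2 alone at the higher level. Nothing measured here accounts for this separation, and no independent evidence bears on why the groups on this carbon fall as they do.

The compounds shown leave open whether the higher number of compound 2 belongs to diethylamino specifically or would extend to other amides without an amide hydrogen, such as those of dimethylamine or pyrrolidine, and how a free carboxylic acid or a longer chain on the ester oxygen would read at this carbon. As each number comes from a single concentration, they also leave open how the potencies of these compounds compare.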